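A propyl amide becomes a phenyl amide on a shared core

The compounds below may be only part of what the source reports. "The series", "measured", "known", "first", "only" and "open" are said of these compounds alone.

Measured so far:
compound 1, `CCCCNC(=O)C1C(C(=O)O)[C@@H]2CC[C@H]1O2`: 10000 nM
compound 2, `CCCNC(=O)C1C(C(=O)O)[C@@H]2CC[C@H]1O2`: 10000 nM

Compound 1 `CCCCNC(=O)C1C(C(=O)O)[C@@H]2CC[C@H]1O2` and compound 2 `CCCNC(=O)C1C(C(=O)O)[C@@H]2CC[C@H]1O2` share the same core and differ only in the chain on the amide nitrogen. In an ADME assay on A2780 cells (Homo sapiens) for cytotoxicity, read by MTT assay, with a stated time of 72 h (on this read-out higher numbers stand for weaker inhibition of growth and lower numbers for stronger inhibition of growth), compound 1 gives 10000 nM, and compound 2 gives 10000 nM. Among the compounds with values here, the single measured step, no change at the digits printed from compound 1 to compound 2 (within the scatter), shows that shortening the chain left the read-out where it was, so compound 2 stands level with compound 1.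

Compound 3 `O=C(O)C1C(C(=O)Nc2ccccc2)[C@H]2CC[C@@H]1O2` differs from compound 2 by phenyl in place of propyl on an amide-type nitrogen. Within the data shown here, no measured step swaps a chain for an aromatic ring, so the available evidence is thin; because no change at the digits printed from compound 1 to compound 2 (within the scatter) showed nothing beyond the scatter, the amide substituent has so far not moved the read-out. Compound 3 is therefore expected to give about 10000 nM, somewhere between 3000 nM and 30000 nM. The expected step is no change at the digits printed from compound 2 to compound 3 (within the scatter), none beyond the scatter, pending the measurement.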

Compound 3, concentration for 50% growth inhibition: 10000 nM
Estimate against measurement, compound 3: no gap at the digits printed; the range from low to high includes it.
By their numbers in this assay, from the lowest: compounds 1, 2 and 3 (each within the scatter of the next).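

In this assay the read-out shows no change at the digits printed from compound 2 to compound 3 (within the scatter) and no change at the digits printed from compound 1 to compound 3 (within the scatter) when an aromatic ring replaces a saturated chain on the amide nitrogen. Within the data shown here, the earlier pair compared only two chains of different length, whereas these steps show that a phenyl amide on the shared core also stands level with the propyl and butyl amides. No available measurement offers an explanation for this flat result.

On these data alone, all three compounds carry the same carboxylic acid on the shared core, and what a methyl ester in its place would do remains open. Also open, as far as these compounds go, is whether a benzyl group on the amide nitrogen, or a phenyl ring bearing a chlorine atom or a methoxy group, would shift the read-out away from the level seen here.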